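Swapping a halogenated aryl for a cyanophenyl sulfone

The source may hold more compounds than are shown below. What is called first, only, known or untested is meant among the compounds shown, and "the series" means these compounds.

Among the compounds with values here, compound 2 `Cc1ccc2ncc(S(=O)(=O)c3ccc(F)c(Cl)c3)c(N3CCC(C)CC3)c2c1` gives 93% in an assay on isolated protein for displacement of a labelled ligand from metabotropic glutamate receptor 5 (Homo sapiens), with a stated time of 60 min, tested at 1 uM (on this read-out lower numbers stand for less inhibition and higher numbers for more inhibition at the one concentration tested (going by the name of the read-out)), the highest of the two numbers measured so far. Compound 1 `Cc1ccc2ncc(S(=O)(=O)c3ccc(Cl)c(Cl)c3)c(N3CCC(C)CC3)c2c1` differs from compound 2 by a chloro in place of the fluoro; in this assay compound 1 gives 82%, and the step of a number 11 percentage points higher from compound 1 to compound 2 (beyond the scatter) is modest but beyond the scatter. Compound 3 `Cc1ccc2ncc(S(=O)(=O)c3ccc(C#N)cc3)c(N3CCC(C)CC3)c2c1` has not yet been measured in this assay. It differs from compound 2 in one place: 4-cyanophenyl in place of 3-chloro-4-fluorophenyl on a sulfonyl sulfur. Within the data shown here, the only step measured so far exchanges one halogen for another on the same ring, and no measured step replaces the whole aryl group. Because compound 1 gives 82% and compound 2 gives 93% with halogenated rings, compound 3 is expected to lose some inhibition, a downward step a number 23 percentage points lower from compound 2 to compound 3 (beyond the scatter). Compound 3 is therefore estimated at 70%, within a range from 40% to 95%.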

Compound 3, a percentage reported as inhibition, at one concentration (the size of the read-out at that concentration, not a potency): 55%
Compound 3: the middle estimate sits 15 percentage points above what was measured; the range from low to high includes it.
By their numbers in this assay, from the lowest: compound 3; then compound 1; then compound 2.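

In this assay, putting 4-cyanophenyl in place of 3-chloro-4-fluorophenyl on a sulfonyl sulfur gives a number 38 percentage points lower from compound 2 to compound 3 (beyond the scatter), a large step that shows the whole aryl group at this position matters far more than the halogen exchange alone, which gave a number 11 percentage points higher from compound 1 to compound 2 (beyond the scatter). The same replacement of 3,4-dichlorophenyl gives a number 27 percentage points lower from compound 1 to compound 3 (beyond the scatter), so the loss appears from both halogenated starting points, and both halogenated rings stand above the 4-cyanophenyl ring on this read-out. Nothing available bears on why this ring gives less inhibition.

The change removes both halogens and adds the nitrile in one move, so the compounds shown cannot separate the two. Going by these compounds, how an unsubstituted phenyl or a 4-methoxyphenyl would read on the same sulfonyl sulfur remains open.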